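A few compounds are considered here, and "the series" means these few. Any claim that something is new, unique, unknown or untested is made for them only; others in the source may bear on it.

Compound 1 `CNC(=O)CN1CCC(c2cc3c(-c4ccc(=O)n(C(C)C)c4)ccnc3[nH]2)CC1` gives 89 mL/min/kg
Compound 2 `COc1cc(F)ccc1-c1ccnc2[nH]c(C3CCN(CC(=O)N(C)C)CC3)cc12` gives 51 mL/min/kg
Compound 3 `COc1cc(C(=O)N2CCCC2)ccc1-c1ccnc2[nH]c(C3CCOCC3)cc12` gives 22 mL/min/kg

All three numbers come from an ADME assay (Rattus norvegicus, strain Han-wistar) for pharmacokinetics, at a dose of 1.5 umol/kg by the intravenous route; on this read-out higher numbers stand for fast clearance and lower numbers for slow clearance. Compound 1 stands at the fast-clearance end of this small set: its number lies within the usual scatter of the number for compound 2, while compound 3 lies lower by more than the scatter. No two of these compounds differ in one place only, so no measured step shows what a single change does here.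

Compound 4 `CC(C)n1cc(-c2ccnc3[nH]c(C4CCN(CC(=O)N5CCCCC5)CC4)cc23)ccc1=O` has not been measured yet. It keeps the core of compound 1 and changes one group: piperidin-1-yl in place of methylamino on a carbonyl carbon. Read one bond further out, this is methylcarbamoyl to (piperidin-1-yl)carbonyl.

The only hint is indirect. Compound 2, whose amide also has no hydrogen on its nitrogen, gives 51 mL/min/kg in this assay, but it differs elsewhere too, so this support is weak. No shift beyond the scatter is therefore expected, with only a slight lean towards a lower number. The estimated step is a 1.2-fold lower number from compound 1 to compound 4 (0.07 log units; within the scatter), which stays within the scatter. For compound 4 the estimate is 75 mL/min/kg, with an expected range of 45 mL/min/kg to 115 mL/min/kg.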

Compound 4, clearance: 159 mL/min/kg
Estimate against measurement, compound 4: 2.1-fold (0.33 log units) below; measured number outside the range, above it.
By their numbers in this assay, from the lowest: compound 3; then compounds 2, 1 and 4 (each within the scatter of the next, the first and the last beyond it).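

Among these compounds, compound 1 and compound 4 differ in one place only, so this pair gives the first direct reading of a single change in this assay: replacing methylamino on the carbonyl carbon with piperidin-1-yl, which brings in a six-membered non-aromatic ring and removes the amide hydrogen, gives a 1.8-fold higher number from compound 1 to compound 4 (0.25 log units; within the scatter) and so does not separate the two compounds. In this one pair, then, a much larger group without a hydrogen-bond donor can stand at this position with no clear shift in clearance, and both compounds share the same numerical neighbourhood at the fast-clearance end of the set. Nothing measured here accounts for the clearance of either compound.

Among the compounds shown here, a single pair cannot show whether the same swap would give a similar result with a different group on the shared core, such as the one carried by compound 2. It also leaves open how clearance would respond to other groups on this carbonyl carbon, for instance morpholin-4-yl or a longer chain ending in an amine.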